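A few compounds are considered here, and "the series" means these few. Any claim that something is new, unique, unknown or untested is made for them only; others in the source may bear on it.

Compound 1 `O=C(CN(c1ncnc2c1ncn2C1CCCCO1)C1CC1)NCC(=O)OCc1ccccc1` belongs to a small set of three analogues built on a shared core. In a functional assay on the whole organism (Tail, strain ICR) with Mus musculus as the target, in the tail flick test, with a stated time of 120 min, at a dose of 25 umol/kg by the oral route (a higher number here means a stronger effect of the compound at the dose given, a lower number a weaker effect), compound 1 gives 17.2%, the second highest of the three numbers; it sits within the scatter of compound 2 `N=C(N)NCCC[C@H](NC(=O)CN(c1nc(Cl)nc2[nH]cnc12)C1CC1)C(=O)OCc1ccccc1`, which gives 10.2%, and well below compound 3 `O=C(CN(c1nc(Cl)nc2[nH]cnc12)C1CC1)N[C@@H](CCC(=O)OCc1ccccc1)C(=O)OCc1ccccc1`, which gives 45.9%. Compound 4 `O=C(CN(c1ncnc2c1ncn2C1CCCCO1)C1CC1)N[C@@H](CC(=O)OCc1ccccc1)C(=O)OCc1ccccc1` differs from compound 1 by (benzyloxycarbonyl)methyl in place of hydrogen on a saturated chain carbon bound to an amide-type nitrogen and a carbonyl carbon. Among the measured compounds shown here, the only measured step that bears on this is a number 35.7 percentage points higher from compound 2 to compound 3 (beyond the scatter), where a benzyl-ester-bearing chain likewise entered the same position of the chain. On that basis compound 4 is expected to show a rise, a number 17.8 percentage points higher from compound 1 to compound 4 (beyond the scatter), in this assay. The estimate for compound 4 is therefore 35%, with a range from 15% to 55%.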

Compound 4, a percentage reported as activity, at one dose (the size of the read-out at that dose, not a potency): 7.82%
Estimate against measurement, compound 4: 27.2 percentage points above; the whole stated range lies above it.
By their numbers in this assay, from the lowest: compounds 4, 2 and 1 (each within the scatter of the next); then compound 3.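

On the core of compound 1, placing (benzyloxycarbonyl)methyl on this saturated chain carbon gives, in this assay, a number 9.4 percentage points lower from compound 1 to compound 4 (within the scatter), so this change does not reproduce the rise of a number 35.7 percentage points higher from compound 2 to compound 3 (beyond the scatter). A benzyl ester on a chain at this position therefore does not bring a higher read-out in every compound shown. Nothing available explains this result.

Still open, as far as these compounds go, is how a free carboxylic acid or an amine at this place would read on this core. Also open, from the compounds shown here alone, is whether a longer chain carrying the benzyl ester would differ from (benzyloxycarbonyl)methyl.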